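The source may hold more compounds than are shown below. What is called first, only, known or untested is meant among the compounds shown, and "the series" means these compounds.

Three compounds share one core and carry different groups on it. In a functional assay on PC-3 cells (Homo sapiens) for inhibition, read by MTT assay, with a stated time of 72 h (on this read-out higher numbers stand for weaker inhibition and lower numbers for stronger inhibition), compound 1 `CN1CCN(c2cc(C(F)(F)F)nc(SCc3ccc(C(F)(F)F)cc3)n2)CC1` gives 34700 nM and compound 2 `FC(F)(F)c1ccc(CSc2nc(N3CCN(c4ccccc4)CC3)cc(C(F)(F)F)n2)cc1` gives 42700 nM while compound 3 `FC(F)(F)c1ccc(CSc2nc(Sc3nnnn3-c3ccccc3)cc(C(F)(F)F)n2)cc1` gives 45300 nM on the same read-out. Compound 3 therefore stands level with the other two, within the usual scatter of both.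

The next compound, compound 4 `FC(F)(F)c1ccc(CSc2nc(Sc3ncc(-c4ccncc4)s3)cc(C(F)(F)F)n2)cc1`, keeps all of compound 3 except one group. The change 5-(pyridin-4-yl)-1,3-thiazol-2-yl in place of 1-phenyl-1H-tetrazol-5-yl on a sulfur is 5-(pyridin-4-yl)-1,3-thiazol-2-yl in place of 1-phenyl-1H-tetrazol-5-yl on a sulfur. For the measured compounds named here, no measured step makes this swap. Going by the values given here, the only measured step of a 1.2-fold higher number from compound 1 to compound 2 (0.09 log units; within the scatter) puts phenyl in place of methyl on an amine nitrogen in a ring. It lies within the scatter, but it concerns a different group, so it bears on the new change only indirectly. Among the compounds with values here, nothing measured so far shows a change of group on this core moving the number beyond the scatter, so no clear shift in this assay is expected in either direction.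

The expected 1.2-fold lower number from compound 3 to compound 4 (0.08 log units; within the scatter) is small and stays within the scatter. The value of compound 4 is estimated at 38000 nM with an expected range from 14000 nM to 80000 nM for now.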

Compound 4, half-maximal inhibitory concentration: 7350 nM
For compound 4 the middle estimate is 5.2-fold (0.71 log units) above the measured one, outside the stated range (below it).
By their numbers in this assay, from the lowest: compound 4; then compounds 1, 2 and 3 (each within the scatter of the next).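

In this assay, for the compounds shown here, the swap on this sulfur gives a 6.2-fold lower number from compound 3 to compound 4 (0.79 log units; beyond the scatter) and so moves the number beyond the scatter, whereas the only earlier step, a 1.2-fold higher number from compound 1 to compound 2 (0.09 log units; within the scatter), stayed within it and concerned a different group. This shows that, on the shared core, the group held on this sulfur can make a real difference to inhibition, here towards stronger inhibition, even though the entering and leaving groups both have 11 heavy atoms, no hydrogen-bond donors and no net charge. Nothing available explains why this swap has such an effect.

Both rings of the group change in this single step, with a 1,3-thiazole replacing the tetrazole and a pyridin-4-yl replacing the phenyl, so the compounds shown leave open which part accounts for the shift. A 5-phenyl-1,3-thiazol-2-yl group or a 1-(pyridin-4-yl)-1H-tetrazol-5-yl group on the same sulfur would keep one ring and change the other, and so would separate the two contributions.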